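This account rests on a few compounds, and the source may have more. Where it says the series, first, only, none or still open, it means among the compounds named here.

Measured in a functional assay on MCF7 cells (Homo sapiens) for inhibition, read by MTT assay, with a stated time of 72 h; on this read-out lower numbers stand for stronger inhibition and higher numbers for weaker inhibition:
- compound 1 `COc1ccccc1-n1c(-c2coc3cc(C)c(Cl)cc3c2=O)nc(-c2ccccc2)c1-c1ccccc1` gives 25000 nM
- compound 2 `Cc1cc2occ(-c3nc(-c4ccccc4)c(-c4ccccc4)n3-c3ccc(Cl)c(Cl)c3)c(=O)c2cc1Cl` gives 1560 nM
- compound 3 `Cc1cc2occ(-c3nc(-c4ccccc4)c(-c4ccccc4)n3-c3cccc([N+](=O)[O-])c3)c(=O)c2cc1Cl` gives 1560 nM

Compound 2 stands level with compound 3, and together they hold the lowest of the three numbers. Compound 4 `Cc1cc2occ(-c3nc(-c4ccccc4)c(-c4ccccc4)n3-c3ccc(Br)cc3)c(=O)c2cc1Cl` has not yet been measured. It carries 4-bromophenyl in place of 3,4-dichlorophenyl on an aromatic nitrogen. Among the measured compounds shown here, three measured steps concern this same place. Two are large, a 16-fold lower number from compound 1 to compound 2 (1.20 log units; beyond the scatter) and a 16-fold lower number from compound 1 to compound 3 (1.20 log units; beyond the scatter), but both leave 2-methoxyphenyl, which plays no part in this change. The closest parallel is no change at the digits printed from compound 2 to compound 3 (within the scatter), which lies within the scatter. No step beyond the scatter is therefore expected in this assay, and the expected step is a 1.2-fold higher number from compound 2 to compound 4 (0.06 log units; within the scatter). For compound 4 the estimate is 1800 nM, with an expected range from 600 nM to 6000 nM.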

Compound 4, half-maximal inhibitory concentration: 1560 nM
For compound 4 the middle estimate is 1.2-fold (0.06 log units) above the measured one; the range from low to high includes it.
By their numbers in this assay, from the lowest: compounds 2, 3 and 4 (each within the scatter of the next); then compound 1.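

In this assay the 4-bromophenyl group on the aromatic nitrogen joins the two earlier groups, with no change at the digits printed from compound 2 to compound 4 (within the scatter) and no change at the digits printed from compound 3 to compound 4 (within the scatter), so three differently substituted phenyl groups now cannot be told apart at this place. Compound 1 with 2-methoxyphenyl remains the only one apart, as a 16-fold lower number from compound 1 to compound 4 (1.20 log units; beyond the scatter) shows for this new group too. No evidence is available that explains this pattern.

As far as these compounds go, it remains open whether 4-methoxyphenyl would sit with these three compounds or with compound 1. Also open, from the compounds shown here alone, is how a phenyl group carrying an amine or a carboxylic acid would behave here.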